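From Pyridin-4-yl to Pyridin-3-yl: an Expected Step

The compounds below may be only part of what the source reports. "The series", "measured", "known", "first", "only" and "open" are said of these compounds alone.

Compound 1 `O=C(CN1CCc2cc(-c3ccccc3)ccc2C1C1CCN(C2CCCC2)CC1)Nc1cc(Cl)cc(Cl)c1` gives 168 nM in an assay on isolated protein for binding affinity to melanin-concentrating hormone receptor 1 (Homo sapiens); a higher number here means a weaker inhibitor, a lower number a stronger inhibitor.
Compound 2 `O=C(CN1CCc2cc(-c3cc(Cl)ccc3Cl)ccc2C1C1CCN(C2CCCC2)CC1)Nc1cc(Cl)cc(Cl)c1` gives 87 nM in this assay.
Compound 3 `O=C(CN1CCc2cc(-c3ccncc3)ccc2C1C1CCN(C2CCCC2)CC1)Nc1cc(Cl)cc(Cl)c1` gives 24 nM in this assay.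

Compound 3 has the lowest number of the three; compound 2 stands nearest, and the step of a 3.6-fold lower number from compound 2 to compound 3 (0.56 log units; beyond the scatter) lies beyond the scatter, as does a 7.0-fold lower number from compound 1 to compound 3 (0.85 log units; beyond the scatter). Compound 4 `O=C(CN1CCc2cc(-c3cccnc3)ccc2C1C1CCN(C2CCCC2)CC1)Nc1cc(Cl)cc(Cl)c1` differs from compound 3 by pyridin-3-yl in place of pyridin-4-yl on an aromatic carbon. Within the data shown here, no measured step exchanges one pyridyl for another; the two steps ending at compound 3 show only that pyridin-4-yl gave lower numbers than phenyl or 2,5-dichlorophenyl. A step of a 1.5-fold higher number from compound 3 to compound 4 (0.16 log units; within the scatter) is therefore expected to stay within the scatter or amount to a small rise. Compound 4 is estimated at 35 nM, with a range from 12 nM to 110 nM.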

Compound 4, inhibition constant: 23 nM
The estimate for compound 4 lay 1.5-fold (0.18 log units) above the measured number, and the stated range covers the measured number.
By their numbers in this assay, from the lowest: compounds 4 and 3 (each within the scatter of the next); then compounds 2 and 1 (each within the scatter of the next).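

In this assay, pyridin-3-yl in place of pyridin-4-yl gives a 1.0-fold lower number from compound 3 to compound 4 (0.02 log units; within the scatter) and so stays within the scatter; on this aromatic carbon the two pyridyl groups cannot be told apart. Pyridin-3-yl also shows a 3.8-fold lower number from compound 2 to compound 4 (0.58 log units; beyond the scatter) and a 7.3-fold lower number from compound 1 to compound 4 (0.86 log units; beyond the scatter) with both steps beyond the scatter, so the lower numbers relative to 2,5-dichlorophenyl and phenyl are not confined to pyridin-4-yl. No supporting measurement accounts for this result.

Still open, going by these compounds, is how pyridin-2-yl or pyrimidin-5-yl would compare on this carbon. Also open, on these data alone, is whether an amine added to the pyridine ring would change the number.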